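Chloro Added to a Trifluoromethyl Quinoline Acid

A few compounds are considered here, and "the series" means these few. Any claim that something is new, unique, unknown or untested is made for them only; others in the source may bear on it.

Measured so far:
compound 1 `Cc1cc(C)c2nc(C3(c4ccc(Cl)cc4)CC3)c(O)c(C(=O)O)c2c1`: 47%
compound 2 `Cc1cc(C(F)(F)F)c2nc(C3(c4ccccc4)CC3)c(O)c(C(=O)O)c2c1`: 40%

In an assay on isolated protein for inhibition of P-selectin glycoprotein ligand 1 (Homo sapiens), read by surface plasmon resonance, tested at 250 uM (on this read-out lower numbers stand for less inhibition and higher numbers for more inhibition at the one concentration tested (going by the name of the read-out)), compound 1 gives 47% and compound 2 gives 40%. Compound 2 stands lowest of the two numbers, yet compound 1 sits higher by an amount within the usual scatter, so no order between them can be read. Compound 3 `Cc1cc(C(F)(F)F)c2nc(C3(c4ccc(Cl)cc4)CC3)c(O)c(C(=O)O)c2c1` is not yet measured; it differs from compound 2 by chloro in place of hydrogen on an aromatic carbon. For the measured compounds named here, no measured pair shows this change alone, so only a small step is expected, toward more inhibition if anything, about a number 5 percentage points higher from compound 2 to compound 3 (within the scatter). For compound 3 the expected value in this assay is 45%, lying between 30% and 60%.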

Compound 3, a percentage reported as inhibition, at one concentration (the size of the read-out at that concentration, not a potency): 65%
The estimate for compound 3 lay 20 percentage points below the measured number, and the stated range ends below it.
By their numbers in this assay, from the lowest: compounds 2 and 1 (each within the scatter of the next); then compound 3.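

In this assay, the change from phenyl to 4-chlorophenyl proves more than a small adjustment, giving a number 25 percentage points higher from compound 2 to compound 3 (beyond the scatter) when the rest of the molecule stays the same. Trifluoromethyl in place of methyl on an aromatic carbon also counts once chloro is present, giving a number 18 percentage points higher from compound 1 to compound 3 (beyond the scatter) in this pair. Nothing measured here explains either step. As far as these compounds go, whether fluoro, methoxy or an amine at the chloro position would match chloro remains open. So does whether chloro would give a similar step with methyl in place of trifluoromethyl.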